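Replacing 3-fluorophenyl with 6-fluoropyridin-3-yl in compound 3

The source may hold more compounds than are shown below. What is called first, only, known or untested is meant among the compounds shown, and "the series" means these compounds.

In a functional assay on MCF7 cells (Homo sapiens) for antiproliferative activity, read by sulforhodamine B assay, with a stated time of 48 h (on this read-out higher numbers stand for weaker inhibition and lower numbers for stronger inhibition), compound 3 (`COc1ccc(/C=C/C(=O)c2ccccc2-c2cccc(F)c2)cc1`) gives 640 nM and compound 1 (`COc1ccc(/C=C/C(=O)c2ccccc2-c2ccc(F)cc2)cc1`) gives 670 nM, two values within the scatter of each other, while compound 2 (`Cc1ccc(/C=C/C(=O)c2ccccc2-c2ccc(F)cc2)o1`) gives 23000 nM. Compound 4 (`COc1ccc(/C=C/C(=O)c2ccccc2-c2ccc(F)nc2)cc1`) carries 6-fluoropyridin-3-yl in place of 3-fluorophenyl on an aromatic carbon. The closest evidence is a 1.0-fold lower number from compound 1 to compound 3 (0.02 log units; within the scatter), a change at this same place that stays within the scatter. The large 34-fold higher number from compound 1 to compound 2 (1.54 log units; beyond the scatter) arises at a different place and bears only weakly. Among the measured compounds shown here, no measured step brings a hetero atom into the ring at this place, so the forecast is uncertain. A modest rise is expected in this assay, with the estimated step being a 1.6-fold higher number from compound 3 to compound 4 (0.19 log units; within the scatter). For compound 4 the estimated value is 1000 nM, with an expected range from 350 nM to 3500 nM.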

Compound 4, half-maximal inhibitory concentration: 2700 nM
Compound 4: the middle estimate sits 2.7-fold (0.43 log units) below what was measured, and the stated range covers the measured number.
By their numbers in this assay, from the lowest: compounds 3 and 1 (each within the scatter of the next); then compound 4; then compound 2.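

In this assay, 3-fluorophenyl and 4-fluorophenyl had given values within the scatter of each other, so this place had seemed tolerant of where the fluorine stood. A ring nitrogen proves less tolerated: 6-fluoropyridin-3-yl gives a step beyond the scatter against both phenyl compounds (a 4.2-fold higher number from compound 3 to compound 4 (0.63 log units; beyond the scatter); a 4.0-fold higher number from compound 1 to compound 4 (0.61 log units; beyond the scatter)). No measurement given here explains this rise.

From the compounds shown here alone, what remains open is whether the rise follows the ring nitrogen itself or its location in the ring. A pyridin-4-yl ring, or an amine in place of the fluorine, would bear on that question.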